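Swapping Phenyl for Chloromethyl on a Shared Core

The source may report more compounds than this note shows. Statements on the series, on what has been measured and on what is new or still open speak of the compounds shown alone.

Of the compounds shown here, three built on one shared core have been tested in a functional assay on MCF7 cells (Homo sapiens) for cytotoxicity, read by MTT assay, with a stated time of 48 h; on this read-out higher numbers stand for weaker inhibition and lower numbers for stronger inhibition. Compound 1 `CNC(=O)CSc1nc2ccc(NC(=O)c3ccccc3)cc2s1` gives 34400 nM in this assay. Compound 2 `CNC(=O)CSc1nc2ccc(NC(=O)CCl)cc2s1` differs from compound 1 in one place: chloromethyl in place of phenyl on a carbonyl carbon. In this assay compound 2 gives 5000 nM, and the change brings a 6.9-fold lower number from compound 1 to compound 2 (0.84 log units; beyond the scatter). Compound 3 `COc1ccc(CNC(=O)CSc2nc3ccc(NC(=O)c4ccccc4)cc3s2)cc1` differs from compound 1 in another place: 4-methoxyphenyl in place of hydrogen on a saturated chain carbon bound to an amide-type nitrogen. In this assay compound 3 gives 21200 nM, which amounts to a 1.6-fold lower number from compound 1 to compound 3 (0.21 log units; within the scatter), so compound 1 and compound 3 cannot be told apart on this read-out.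

Compound 4 `COc1ccc(CNC(=O)CSc2nc3ccc(NC(=O)CCl)cc3s2)cc1` has not yet been measured. It differs from compound 3 in one place: chloromethyl in place of phenyl on a carbonyl carbon. This is the same change that turns compound 1 into compound 2, made at a place described in the same words, and it occurs twice among these four compounds. The two starting points, compound 1 and compound 3, differ only in the change already described between them. Among the compounds with values here, on the one earlier instance, a step of similar size is expected here: compound 4 is expected to show a 6.1-fold lower number from compound 3 to compound 4 (0.78 log units; beyond the scatter). That expectation rests on one pair only, because the earlier step was a 6.9-fold lower number from compound 1 to compound 2 (0.84 log units; beyond the scatter). Compound 4 is estimated at 3500 nM in this assay, with a likely range from 1500 nM to 8000 nM.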

Compound 4, half-maximal inhibitory concentration: 5100 nM
The estimate for compound 4 lay 1.5-fold (0.16 log units) below the measured number; the range from low to high includes it.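

In this assay, chloromethyl in place of phenyl on the carbonyl carbon again gives a step beyond the scatter, a 4.2-fold lower number from compound 3 to compound 4 (0.62 log units; beyond the scatter), and it agrees with the earlier step on the other core: the same change on two cores in this assay, a 6.9-fold lower number (0.84 log units; beyond the scatter) from compound 1 to compound 2 and a 4.2-fold lower number (0.62 log units; beyond the scatter) from compound 3 to compound 4, 1.7-fold (0.22 log units) apart, within the scatter of two such steps. The second change, 4-methoxyphenyl in place of hydrogen on the saturated chain carbon, gives a 1.0-fold higher number from compound 2 to compound 4 (0.01 log units; within the scatter), so compound 2 and compound 4 cannot be told apart on this read-out, and this step also agrees with its earlier counterpart: the same change on two cores in this assay, a 1.6-fold lower number (0.21 log units; within the scatter) from compound 1 to compound 3 and a 1.0-fold higher number (0.01 log units; within the scatter) from compound 2 to compound 4, 1.7-fold (0.22 log units) apart, within the scatter of two such steps. Among these four compounds, each change therefore keeps a similar size when carried from one core to the other, but this rests on only two steps per change in a single assay, and it shows neither that the pattern would hold on other cores nor why the numbers move.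

From the compounds shown here alone, only phenyl and chloromethyl appear on the carbonyl carbon, so it remains open whether a plain methyl, a bromomethyl or a longer chain there would give numbers like those of compound 2 and compound 4. Going by these compounds, only hydrogen and 4-methoxyphenyl appear on the saturated chain carbon, so an unsubstituted phenyl, a pyridine ring or a carboxylic acid at that place also remains open.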